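Compound 2 to compound 4: reworking the amide-side substituent

The source may report more compounds than this note shows. Statements on the series, on what has been measured and on what is new or still open speak of the compounds shown alone.

Three compounds have numbers in an assay on HEK293 cells for displacement of a labelled ligand from Melanocortin receptor 4 (Homo sapiens); on this read-out lower numbers stand for stronger inhibition and higher numbers for weaker inhibition. Compound 1 `CC(C)C[C@H](N)c1ccccc1N1CCN(C(=O)[C@H](C)Cc2ccc(Cl)cc2F)CC1` gives 67 nM. Compound 3 `CC(C)C[C@H](N)c1ccccc1N1CCN(C(=O)[C@H](C)Cc2ccc(Cl)cc2Cl)CC1` gives 16 nM. Compound 2 `Cc1ccc(OCC(=O)N2CCN(c3ccc(C(F)(F)F)cc3[C@@H](N)CC(C)C)CC2)cc1` gives 4400 nM, the highest of the three numbers; compound 1 is nearest to it and compound 3 furthest, both beyond the scatter.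

Compound 4 `CC(C)C[C@H](N)c1cc(C(F)(F)F)ccc1N1CCN(C(=O)CCC(=O)c2ccc(Cl)cc2)CC1` has not been measured in this assay. It differs from compound 2 in one place: ((4-chlorophenyl)carbonyl)methyl in place of 4-methylphenoxy on a saturated chain carbon bound to a carbonyl carbon. Among the compounds with values here, no measured step covers this exchange. Within the data shown here, the only step on record, a 4.2-fold lower number from compound 1 to compound 3 (0.62 log units; beyond the scatter), concerns a halogen swap on an aromatic carbon and is modest; it does not speak to a change of the whole group on the carbon bound to the carbonyl. Compound 4 does carry a 4-chlorophenyl ring, as compounds 1 and 3 do, while its core matches that of compound 2. The direction of the step is therefore uncertain. With a wide range around it, the expected step is about a 7.3-fold lower number from compound 2 to compound 4 (0.87 log units; beyond the scatter).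

For compound 4 the estimate in this assay is 600 nM, between 100 nM and 3500 nM.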

Compound 4, inhibition constant: 820 nM
Beside the measured number, compound 4's estimate is 1.4-fold (0.14 log units) below it, within the range that was stated.
By their numbers in this assay, from the lowest: compound 3; then compound 1; then compound 4; then compound 2.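

In this assay, ((4-chlorophenyl)carbonyl)methyl in place of 4-methylphenoxy on a saturated chain carbon bound to a carbonyl carbon gives a 5.4-fold lower number from compound 2 to compound 4 (0.73 log units; beyond the scatter), so a change of the whole group at this position moves the number, and the move is modest. Both groups hold one six-membered aromatic ring of carbon only and the same count of hydrogen-bond acceptors, while the entering group is larger and brings a double bond outside aromatic rings. Nothing on record accounts for the step.

This single exchange does not separate the contributions of the chlorine, the carbonyl and the oxygen that leaves. It also leaves open how the number would respond to an amine, a carboxylic acid or a longer chain carrying the 4-chlorophenyl ring at this position.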